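The source may report more compounds than this note shows. Statements on the series, on what has been measured and on what is new or still open speak of the compounds shown alone.

Measured compounds:
- compound 1, `OC(CCn1nc2c(Br)c(Br)c(Br)c(Br)c2n1)c1cccc(Br)c1`: 102%
- compound 2, `C[C@@H](O)CCn1nc2c(Br)c(Br)c(Br)c(Br)c2n1`: 86%

The two measured compounds share a core and differ in the chain carrying the hydroxyl. In a functional assay on MCF7 cells (Homo sapiens) for antiproliferative activity, read by MTT assay, with a stated time of 48 h, tested at 12.5 uM (a higher number here means a weaker effect of the compound at the concentration tested, a lower number a stronger effect), compound 1 gives 102%, the highest of the two numbers, while compound 2 gives 86%, a lower number, a gap that is beyond the scatter of this assay.

Compound 3, `CC(O)CCn1nc2c(Br)c(Br)c(Br)c(Br)c2n1`, has not been measured in this assay. It differs from compound 1 in one place: methyl in place of 3-bromophenyl on a saturated chain carbon bound to an oxygen on a saturated carbon and a saturated chain carbon. Within the data shown here, no step between measured compounds is given for this kind of change, so its size must be estimated. Compound 3 is expected to sit somewhat lower than compound 1, with a step of a number 14 percentage points lower from compound 1 to compound 3 (beyond the scatter) that is at the edge of what the scatter allows. Compound 2 gives 86% in this assay and carries a methyl on the chain carbon that bears the hydroxyl. Compound 3 carries a methyl at that place as well, in place of the aryl group of compound 1. Compound 3 is therefore estimated at 88%, with a range from 76% to 100%.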

Compound 3, a percentage reported as activity, at one concentration (the size of the read-out at that concentration, not a potency): 79%
Beside the measured number, compound 3's estimate is 9 percentage points above it; the range from low to high includes it.
By their numbers in this assay, from the lowest: compounds 3 and 2 (each within the scatter of the next); then compound 1.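

In this assay, methyl in place of 3-bromophenyl on a saturated chain carbon bound to an oxygen gives a number 23 percentage points lower from compound 1 to compound 3 (beyond the scatter), the first measure of this single change, and the lower number means a stronger effect at the concentration tested. Compound 3 reaches 79%, so removing the aryl group at this position leaves a compound with a stronger effect than compound 1, although a large part of the read-out remains. The drawn configuration at the same carbon gives a number 7 percentage points lower from compound 2 to compound 3 (within the scatter), so this pair shows no difference that can be told from the scatter, and the comparison rests on one stereo element only: the fact that one of compounds 2 and 3 is drawn with a defined configuration and the other without, at the place where they differ

Only methyl and 3-bromophenyl stand at this carbon in the compounds shown, so it remains open how an unsubstituted phenyl, an ethyl or a longer chain would read in this assay. Also open, going by these compounds, are the stereocentre drawn S and the effect of an amine or a carboxylic acid in place of the hydroxyl.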